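From Difluoromethyl to Trifluoromethyl in a Two-Compound Series

The compounds below may be only part of what the source reports. "The series", "measured", "known", "first", "only" and "open" are said of these compounds alone.

Of the compounds shown here, two have numbers so far. Compound 1 `N#Cc1ncncc1-c1nc2cc(F)c(F)cc2n1C1CC1` and compound 2 `N#Cc1ccc2nc(-c3cncnc3C(F)F)n(C3CC3)c2n1` share a common core. In an assay on cells for inhibition of cytochrome P450 11B2, mitochondrial (Homo sapiens), read by HPLC, with a stated time of 90 min (on this read-out lower numbers stand for stronger inhibition and higher numbers for weaker inhibition), compound 1 gives 13 nM. In this assay compound 2 gives 29 nM, the highest of the two numbers; compound 1 sits at a lower number, beyond the scatter. Compound 3 `N#Cc1ccc2nc(-c3cncnc3C(F)(F)F)n(C3CC3)c2n1` is not yet measured. It differs from compound 2 by fluoro in place of hydrogen on a saturated chain carbon bound to an aromatic carbon and two fluorine atoms, that is, difluoromethyl becomes trifluoromethyl. Among the measured compounds shown here, no measured pair shows this step, so the size expected for a 1.0-fold higher number from compound 2 to compound 3 (0.01 log units; within the scatter) is within the scatter, in either direction. Compound 3 is therefore estimated at 30 nM, with a range from 10 nM to 90 nM.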

Compound 3, half-maximal inhibitory concentration: 24 nM
The estimate for compound 3 lay 1.3-fold (0.10 log units) above the measured number; low and high end bracket the measured number.
By their numbers in this assay, from the lowest: compounds 1, 3 and 2 (each within the scatter of the next, the first and the last beyond it).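

Among the compounds shown here, at this carbon, the change from difluoromethyl to trifluoromethyl gives a 1.2-fold lower number from compound 2 to compound 3 (0.08 log units; within the scatter) in this assay and is the first single-place comparison. The hydrogen on this carbon is therefore not needed to hold inhibition at this level, and fluoro serves equally well there. No available evidence explains why the two groups read alike.

From the compounds shown here alone, whether this position stays as undemanding with a group lacking fluorine, such as methyl, an amine or a longer chain, remains open. Compound 1 differs from compound 2 and compound 3 in more than one place, so it cannot settle this question.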